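This account rests on a few compounds, and the source may have more. Where it says the series, first, only, none or still open, it means among the compounds named here.

Compound 1 `COc1ccc(/C=C2\S/C(=N\c3csc(-c4ccc(Cl)cc4)c3)NC2=O)cc1` gives 1200 nM in a functional assay on MDA-MB-231 cells (Homo sapiens) for cytotoxicity, read by MTT assay, with a stated time of 72 h; a higher number here means a weaker inhibitor, a lower number a stronger inhibitor.
Compound 2 `Cc1ccc(/C=C2\S/C(=N\c3csc(-c4ccc(Cl)cc4)c3)NC2=O)cc1` gives 900 nM in this assay.
Compound 3 `COc1cccc(N2C(=O)CS/C2=N\c2csc(-c3ccc(C)cc3)c2)c1` reaches only a limit of the assay, > 50000 nM in this assay.

Compounds 1 and 2 share one core and differ in a single place: methoxy in place of methyl on an aromatic carbon. That change made a 1.3-fold higher number from compound 2 to compound 1 (0.12 log units; within the scatter), so the two numbers cannot be told apart in this assay. Compound 3 is built on a different core; how its core differs from that of compound 2 is not broken down here. For compound 3 the number is not a measurement but a limit, because it sits at the limit of > 50000 nM in this assay, at which 1 of the 3 values shown sits.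

Compound 4 `COc1ccc(-c2cc(/N=C3\SCC(=O)N3c3cccc(OC)c3)cs2)cc1` is the unmeasured partner of compound 3. It differs from compound 3 in the same way that compound 1 differs from compound 2: methoxy in place of methyl on an aromatic carbon. The place of the change is described in the same words in both pairs, so this counts as the same change, made on a different core.

Since the change made a 1.3-fold higher number from compound 2 to compound 1 (0.12 log units; within the scatter) on the first core, the step on the second core is expected to be a step that the limit leaves unreadable from compound 3 to compound 4, resting on that single earlier pair and on the limit of compound 3. Compound 4 is therefore estimated to give about 60000 nM in this assay, with a range from 20000 nM to 200000 nM, and most likely it will again be reported only as a limit.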

Compound 4, half-maximal inhibitory concentration: 2700 nM
Compound 4: middle estimate off by 22-fold (1.35 log units), on the high side; measured number below the stated range.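

In this assay, methoxy in place of methyl, here 4-methylphenyl to 4-methoxyphenyl, gave an at least 18-fold lower number from compound 3 to compound 4 (1.26 log units; beyond the scatter), so the same change did not behave alike on the two cores: the same change on two cores in this assay, a 1.3-fold higher number (0.12 log units; within the scatter) from compound 2 to compound 1 and an at least 18-fold lower number (1.26 log units; beyond the scatter) from compound 3 to compound 4, at least 24-fold (1.39 log units) apart, beyond the scatter of two such steps

That step gives only a bound and not an exact size, since compound 3 stands at a limit of the assay: the limit of > 50000 nM in this assay, at which 1 of the 4 values shown sits.

Two pairs show only that the outcome of this swap depended on the core in these compounds; they do not explain why, and they give no rule for what the swap would do on any further core.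

The compounds shown leave open how the second core would respond to other groups in the same place, such as an amine, a carboxylic acid or a longer chain like ethoxy, and whether a third core would follow the first or the second. They also leave open what number compound 3 would give if it could be read, and so how large the step on the second core truly is.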